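Chloro to methoxy on the aryl ring of compound 3

The compounds below may be only part of what the source reports. "The series", "measured", "known", "first", "only" and "open" are said of these compounds alone.

Measured compounds:
- Compound 1, `O=C(Nc1ccccc1)c1c(NO)cc(-c2ccc(Cl)cc2)oc1=O`. In an ADME assay on Huh-7 cells (Homo sapiens) for cytotoxicity, read by a luciferase reporter and WST assay, with a stated time of 3 days (on this read-out higher numbers stand for lower toxicity in this test and lower numbers for higher toxicity in this test), compound 1 gives 11000 nM.
- Compound 2, `COc1ccc(-c2cc(NO)c(C(=O)Nc3ccccc3)c(=O)o2)cc1`. In this assay compound 2 gives 16200 nM.
- Compound 3, `Cc1ccc(NC(=O)c2c(NO)cc(-c3ccc(Cl)cc3)oc2=O)cc1`. For compound 3 only a limit of the assay is known: in this assay compound 3 gives > 20000 nM.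

Compound 3 thus stands at the upper edge of what was measured, the limit at which one of the three values sits (the limit of > 20000 nM in this assay, at which 1 of the 3 values shown sits). No number is known for it.

Compound 4, `COc1ccc(-c2cc(NO)c(C(=O)Nc3ccc(C)cc3)c(=O)o2)cc1`, not yet measured, differs from compound 3 in one place: methoxy in place of chloro on an aromatic carbon.

The same exchange was measured once, from compound 1 to compound 2: a 1.5-fold higher number from compound 1 to compound 2 (0.17 log units; within the scatter). That step is within the scatter. The step of an at least 1.8-fold higher number from compound 1 to compound 3 (0.25 log units; that floor lies within the scatter) only sets a floor, also within the scatter. Taken together, no step beyond the scatter is expected for this assay from compound 3 to compound 4, with any shift, if present, toward a higher number; the estimated step is a step that the limit leaves unreadable from compound 3 to compound 4.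

Compound 4 is therefore expected to give about 28000 nM in this assay, within 14000 nM to 60000 nM, most likely again reported only as a limit.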

Compound 4, half-maximal cytotoxic concentration: > 20000 nM
Compound 4 gave a limit, no number; the forecaster's own chance of this, stated with the estimate: 75%; the middle value is on the limit's open side.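

In this assay compound 4 gives > 20000 nM, a limit of the assay and not a number. With the methyl in place, the 4-chlorophenyl and 4-methoxyphenyl compounds both sit at this limit, and the size of the step between compound 3 and compound 4 cannot be read. Methyl in place of hydrogen now has a second reading, an at least 1.2-fold higher number from compound 2 to compound 4 (0.09 log units; that floor lies within the scatter), which can be set against the first: the same change on two cores in this assay, an at least 1.8-fold higher number (0.25 log units; that floor lies within the scatter) from compound 1 to compound 3 and an at least 1.2-fold higher number (0.09 log units; that floor lies within the scatter) from compound 2 to compound 4; the limit leaves it open whether they differ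

On these data alone, whether compound 3 and compound 4 differ at all in this assay remains open: the limit of > 20000 nM in this assay, at which 2 of the 4 values shown sit. Also open is the reading at this position with an amine or a carboxylic acid in place of chloro or methoxy.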